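Adding a methoxy group to a phenyl sulfonate

This account rests on a few compounds, and the source may have more. Where it says the series, first, only, none or still open, it means among the compounds named here.

Compound 1 `CCN1CCN(c2ccc(S(=O)(=O)Oc3cccc(OC)c3)cc2)C1=O` - 7000 nM
Compound 2 `CCCCN1CCN(c2ccc(S(=O)(=O)Oc3ccccc3)cc2)C1=O` - > 100000 nM

In a functional assay on M21 cells (Homo sapiens) for antiproliferative activity, read by sulforhodamine B assay, with a stated time of 48 h (a lower number here means a stronger inhibitor, a higher number a weaker inhibitor), compound 2 reads > 100000 nM, which is a limit of the assay and not a number. Compound 3 `CCCCN1CCN(c2ccc(S(=O)(=O)Oc3cccc(OC)c3)cc2)C1=O` differs from compound 2 in one place: methoxy in place of hydrogen on an aromatic carbon, with methoxy in place of hydrogen on an aromatic carbon, turning phenyl into 3-methoxyphenyl. Carrying that same 3-methoxyphenyl group, but an ethyl chain instead of butyl, compound 1 gives 7000 nM, and this value is the ground for expecting a gain. A large step towards stronger inhibition in this assay is expected, estimated as an at least 16-fold lower number from compound 2 to compound 3 (1.22 log units; beyond the scatter). For compound 3 the estimated value is 6000 nM, with an expected range of 1500 nM to 25000 nM.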

Compound 3, half-maximal inhibitory concentration: 30000 nM
Estimate against measurement, compound 3: 5.0-fold (0.70 log units) below; the whole stated range lies below it.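

In this assay, methoxy in place of hydrogen on the phenyl ring of the butyl compound gives an at least 3.3-fold lower number from compound 2 to compound 3 (0.52 log units; beyond the scatter), so this change strengthens inhibition on the butyl series. Compound 2 stands at a limit of the assay and not at a number, so this step has only one bound: the limit of > 100000 nM in this assay, at which 1 of the 3 values shown sits. With the 3-methoxyphenyl group held fixed, the chain also counts, with butyl in place of ethyl giving a 4.3-fold higher number from compound 1 to compound 3 (0.63 log units; beyond the scatter).

As far as these compounds go, whether the methoxy gain has the same size on the ethyl chain remains open. So does the effect of a hydroxyl or a chlorine in its place, or of a chain longer than butyl.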